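Indazole esters in the platelet assay: compound 3 to compound 4

The compounds below may be only part of what the source reports. "The series", "measured", "known", "first", "only" and "open" are said of these compounds alone.

Measured so far:
compound 1, `CCOC(=O)c1ccc(-c2nn(-c3ccoc3)c3ccccc23)cc1`, 580 nM
compound 2, `CCCn1nc(-c2ccc(C(=O)OCC)cc2)c2ccccc21`, 490 nM
compound 3, `CC(C)OC(=O)c1ccc(-c2nn(Cc3ccccc3)c3ccccc23)cc1`, > 10000 nM (a limit)

In a functional assay on cells (Platelet, Homo sapiens) for inhibition (a lower number here means a stronger inhibitor, a higher number a weaker inhibitor), compound 1 gives 580 nM and compound 2 gives 490 nM; the step of a 1.2-fold lower number from compound 1 to compound 2 (0.07 log units; within the scatter) concerns the group on the aromatic nitrogen only. For compound 3 the assay reports only a limit, > 10000 nM, so compound 3 sits at the limit of > 10000 nM in this assay, at which 1 of the 3 values shown sits, and its true number is not known.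

Compound 4, `CCOC(=O)/C=C/c1ccc(-c2nn(Cc3ccccc3)c3ccccc23)cc1`, differs from compound 3 by 2-(ethoxycarbonyl)ethenyl in place of isopropoxycarbonyl on an aromatic carbon. No measured step touches this position: the one step shown, from compound 1 to compound 2, alters the aromatic nitrogen and lies within the scatter. The ester directly on the ring is shared by compound 1 and compound 2, but both carry a different nitrogen group from compound 3, so they give no direct reading on this change. Because compound 3 sits at the limit of > 10000 nM in this assay, at which 1 of the 3 values shown sits, the step of an at least 1.6-fold lower number from compound 3 to compound 4 (0.22 log units; that floor lies within the scatter) is expected to be uncertain in both size and direction. Compound 4 is estimated at 6000 nM in this assay, within 1500 nM to 20000 nM.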

Compound 4, half-maximal inhibitory concentration: > 10000 nM
Compound 4 ended at the assay's limit (the forecaster's own chance of this, stated with the estimate: 40%); at least 1.6-fold (0.22 log units) between middle value and limit.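

In this assay compound 3 gives > 10000 nM, a limit. For the compounds shown here, compound 4 gives > 10000 nM, also a limit, so no step between the two can be read. On these data alone, whether 2-(ethoxycarbonyl)ethenyl in place of isopropoxycarbonyl shifts the number at all, and in which direction, stays open.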